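A few compounds are considered here, and "the series" means these few. Any claim that something is new, unique, unknown or untested is made for them only; others in the source may bear on it.

Two measured compounds set the frame. Compound 1 `Cc1nn(-c2ncnc3nc[nH]c23)c2c1C(OCc1ccccc1F)CC(=O)N2` gives 78 nM in a functional assay on HEK293 cells for agonist activity at G-protein coupled receptor 39 (Homo sapiens), read by scintillation proximity assay and inositol phosphate accumulation, with a stated time of 75 min; a higher number here means that more compound is needed for the effect, a lower number that less compound is needed. Among the measured compounds shown here, compound 2 `Cc1nn(-c2ncnc3nc[nH]c23)c2c1C(OC(=O)c1ccc(F)cc1)CC(=O)N2` gives 245 nM in this assay, the highest of the two numbers; its only neighbour is reached by the step of a 3.1-fold higher number from compound 1 to compound 2 (0.50 log units; beyond the scatter). Compound 3 `Cc1nn(-c2ncnc3nc[nH]c23)c2c1C(OCCn1cccn1)CC(=O)N2` has not yet been measured. It differs from compound 2 in one place: 2-(1H-pyrazol-1-yl)ethyl in place of (4-fluorophenyl)carbonyl on an oxygen on a saturated carbon. For the measured compounds named here, the single measured step, a 3.1-fold higher number from compound 1 to compound 2 (0.50 log units; beyond the scatter), concerns a different group at the same oxygen and so bears on this change only loosely. The entering group of compound 3, like the 2-fluorobenzyl of compound 1, joins that oxygen through a saturated carbon rather than through a carbonyl, and the number is therefore expected to move downward, by roughly a 2.0-fold lower number from compound 2 to compound 3 (0.31 log units; beyond the scatter) in this assay. Compound 3 is accordingly estimated at 120 nM, within a range from 40 nM to 400 nM.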

Compound 3, half-maximal effective concentration: 2270 nM
Estimate against measurement, compound 3: 19-fold (1.28 log units) below; measured number above the stated range.
By their numbers in this assay, from the lowest: compound 1; then compound 2; then compound 3.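

The saturated carbon on the oxygen does not by itself keep the number low in this assay: compound 1 and compound 3 both have this link, yet the change gives a 29-fold higher number from compound 1 to compound 3 (1.46 log units; beyond the scatter) and so outweighs the carbonyl-to-saturated-carbon difference. The other step, a 9.3-fold higher number from compound 2 to compound 3 (0.97 log units; beyond the scatter), shows that the carbonyl-linked compound 2 needs less compound than the pyrazole-bearing compound 3, so the group attached through the oxygen matters more than the type of link in these three compounds. Here, the two lower numbers belong to the groups with a fluorinated six-membered carbon ring, but no measurement shown gives a reason for the rise.

Still open, from the compounds shown here alone, is whether the pyrazole ring, the ethyl chain or both account for the rise. A 2-phenylethyl group on the same oxygen would help separate these, while an amine at the end of the chain remains an untested kind of group here.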